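Swapping methyl for chloro on a weak inhibitor

The compounds below may be only part of what the source reports. "The series", "measured", "known", "first", "only" and "open" are said of these compounds alone.

Compound 1 `COC(=O)Cn1c(=O)c(S(=O)(=O)c2ccc(F)cc2F)cc2cnc(Nc3ccc4[nH]ccc4c3)nc21`: 10000 nM
Compound 2 `COc1ccc(Nc2ncc3cc(S(=O)(=O)c4ccc(C)cc4)c(=O)n(C)c3n2)cc1`: 100000 nM
Compound 3 `Cn1c(=O)c(S(=O)(=O)c2ccc(F)cc2F)cc2cnc(Nc3cccc4[nH]ccc34)nc21`: 750 nM

All three values come from a functional assay on DU-145 cells (Homo sapiens) for inhibition, read by trypan blue exclusion, with a stated time of 72 h; on this read-out lower numbers stand for stronger inhibition and higher numbers for weaker inhibition. Compound 2, at 100000 nM, has the highest number of the three and is therefore the weakest inhibitor here. The nearest value belongs to compound 1, at 10000 nM, and the furthest to compound 3, at 750 nM. Both gaps lie beyond the scatter of repeated measurements.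

The next compound to be tested is compound 4 `COc1ccc(Nc2ncc3cc(S(=O)(=O)c4ccc(Cl)cc4)c(=O)n(C)c3n2)cc1`. It differs from compound 2 in one place only: chloro in place of methyl on an aromatic carbon. This is chloro in place of methyl on an aromatic carbon, which turns 4-methylphenyl into 4-chlorophenyl, para to a large group.

Going by the values given here, no two measured compounds here differ in just one place, so the data offer no direct guide to this swap. Compounds 1 and 3 differ from compound 2 in more than one place, and their lower numbers say little about a change this small. In this assay the expected change is a 1.4-fold lower number from compound 2 to compound 4 (0.15 log units; within the scatter), which would be no step beyond the scatter. Compound 4 is estimated at 70000 nM, with an expected range from 15000 nM to 150000 nM.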

Compound 4, half-maximal inhibitory concentration: 30000 nM
Compound 4: middle estimate off by 2.3-fold (0.37 log units), on the high side, within the range that was stated.
By their numbers in this assay, from the lowest: compound 3; then compound 1; then compound 4; then compound 2.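

In this assay the swap of methyl for chloro gives a 3.3-fold lower number from compound 2 to compound 4 (0.52 log units; beyond the scatter) and so counts as a modest step, yet one that stands clear of the scatter. Going by these compounds alone, this is the first direct reading at this place on the ring: the group para to the sulfonyl link is not a silent spot, since trading one heavy atom for another, with no hydrogen-bond donor or acceptor and no net charge on either side, is enough to shift the number. Nothing at hand explains the shift, so it stands here as an observation only.

Even with chloro in place, compound 4 sits at 30000 nM and remains a weak inhibitor, so it is open whether a different group at the same place, such as an amine, a nitrile or a carboxylic acid, would move the number further and in which direction. Going by these compounds, it is also open whether the swap of methyl for chloro would give a step of similar size on a compound with a different aniline-side group.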